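Swapping the sulfonyl aryl group: nitro out, bromine in

This account rests on a few compounds, and the source may have more. Where it says the series, first, only, none or still open, it means among the compounds named here.

Measured compounds:
- Compound 1, `COc1ccc(-c2c(I)c(=O)c3c(OC)cc(OC)cc3n2S(=O)(=O)c2ccc(OC)cc2)cc1`: in an ADME assay on BJ cells (Homo sapiens) for antiproliferative activity, with a stated time of 72 h (a lower number here means that less compound is needed, a higher number that more compound is needed for the effect), compound 1 gives > 34400 nM, which is a limit of the assay and not a number.
- Compound 2, `COc1ccc(-c2cc(=O)c3c(OC)cc(OC)cc3n2S(=O)(=O)c2cccc([N+](=O)[O-])c2)cc1`: in this assay compound 2 gives > 39600 nM, again a limit of the assay rather than a number.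

For the measured compounds named here, compound 2 therefore stands at the edge of what this assay can report, and so does the only other measured compound, compound 1 (the limit of > 34400 nM in this assay, at which 1 of the 2 values shown sits, (the limit of > 39600 nM in this assay, at which 1 of the 2 values shown sits)). Nothing here separates the two within the scatter of the measurement.

Compound 3 is `COc1ccc(-c2cc(=O)c3c(OC)cc(OC)cc3n2S(=O)(=O)c2ccc(Br)cc2)cc1`. It differs from compound 2 in one place: 4-bromophenyl in place of 3-nitrophenyl on a sulfonyl sulfur.

Going by the values given here, no step between measured compounds is available, so there is no measured basis for the size or direction of this change. Since compound 2 sits at a limit, the plainest expectation is that compound 3 also reaches no measurable value, with no change beyond the scatter. Compound 3 is expected to give 40000 nM, with a range from 10000 nM to 150000 nM. The expected step is a step that the limit leaves unreadable from compound 2 to compound 3.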

Compound 3, half-maximal effective concentration: > 86200 nM
Compound 3: a limit, no number (the forecaster's own chance of this, stated with the estimate: 75%); middle value at least 2.1-fold (0.33 log units) away from the limit.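

In this assay compound 2 and compound 3 both end at a limit of the assay and not at a number, so the step between them, 4-bromophenyl in place of 3-nitrophenyl on a sulfonyl sulfur, cannot be read. The compounds shown leave open what concentration, if any, gives the effect in this assay and whether the group on the sulfonyl sulfur changes it.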